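Compound 4 against the limit of compound 2

The source may report more compounds than this note shows. Statements on the series, on what has been measured and on what is new or still open speak of the compounds shown alone.

Measured so far in a physicochemical assay for solubility (a lower number here means a less soluble compound, a higher number a more soluble compound), for three compounds:
- compound 1 (`CNC(=O)c1cc(C(=O)NC2CC2)cn(Cc2ccc(C)cc2)c1=O`) gives 24 ug/mL
- compound 2 (`CNC(=O)c1cc(C(=O)NCCC2CCOCC2)cn(Cc2ccccc2)c1=O`) gives >= 127 ug/mL as a limit
- compound 3 (`CNC(=O)c1cc(C(=O)NC2CC2)cn(Cc2cccc(OC)c2)c1=O`) gives 79 ug/mL

Compound 2 stands at the limit of >= 127 ug/mL in this assay, at which 1 of the 3 values shown sits, and this is a limit, not a number. Among the measured compounds shown here, compound 4 (`CNC(=O)c1cc(C(=O)NCCC(C)C)cn(Cc2ccccc2)c1=O`) has no measurement yet. Its change from compound 2 is isopropyl in place of oxan-4-yl on a saturated chain carbon, two bonds along the chain from an amide-type nitrogen and nothing else. Cut one bond further out, the same difference reads 2-(oxan-4-yl)ethyl to isopentyl.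

For the measured compounds named here, no step at this place has been measured. Going by the values given here, the one measured step is a 3.3-fold higher number from compound 1 to compound 3 (0.52 log units; beyond the scatter) and it concerns another group, so it serves only as a guide to size. Compound 2 stands at >= 127 ug/mL as a limit, so a number for compound 4 would have to come out lower, and a step of modest size towards a lower number in this assay is expected. A reading at the limit again remains possible. The estimate amounts to an at least 2.3-fold lower number from compound 2 to compound 4 (0.36 log units; beyond the scatter) as an expected step. For compound 4 an estimated 55 ug/mL is expected, within an estimated range from 20 ug/mL to 130 ug/mL at this stage.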

Compound 4, solubility: 10 ug/mL
Beside the measured number, compound 4's estimate is 5.5-fold (0.74 log units) above it; measured number outside the range, below it.
By their numbers in this assay, from the lowest: compound 4; then compound 1; then compound 3. At a limit, above all of these: compound 2.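

In this assay, the place on a saturated chain carbon, two bonds along the chain from an amide-type nitrogen, now has a measured step: isopropyl in place of oxan-4-yl goes with an at least 12-fold lower number from compound 2 to compound 4 (1.10 log units; beyond the scatter), printed as large and beyond the scatter. The reading for compound 2 is a limit and not a number, so this step gives only a minimum size: the limit of >= 127 ug/mL in this assay, at which 1 of the 4 values shown sits. Among the compounds shown here, the only earlier step, a 3.3-fold higher number from compound 1 to compound 3 (0.52 log units; beyond the scatter), is printed as modest and belongs to a different place, the group on a saturated chain carbon bound to an aromatic nitrogen, so the series now has a measured change at each of these two places.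

The change removes both the ring and its oxygen, and the compounds shown cannot separate the two; cyclohexyl at this place would keep the ring without the oxygen, while a methoxy group on the isopentyl chain would keep an oxygen without the ring. Also open, as far as these compounds go, is how this place responds to groups that can carry a charge, such as a piperidin-4-yl amine or a carboxylic acid.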